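A few compounds are considered here, and "the series" means these few. Any claim that something is new, unique, unknown or untested is made for them only; others in the source may bear on it.

Measured compounds:

Compound 1 `CCn1cc(C(CC)(CC)c2ccc(C#CC(O)(CC)CC)c(C)c2)cc1C(=O)NCCCN(C)C` gives 142 nM in an assay on cells for agonist activity at vitamin D3 receptor (Homo sapiens), read by microscopy; a higher number here means that more compound is needed for the effect, a lower number that less compound is needed.
Compound 2 `CCn1cc(C(CC)(CC)c2ccc(C#CC(O)(CC)CC)c(C)c2)cc1C(=O)NCC(=O)O` gives 54.3 nM in this assay.
Compound 3 `CCn1cc(C(CC)(CC)c2ccc(C#CC(O)(CC)CC)c(C)c2)cc1C(=O)NCCC(=O)O` gives > 50 nM in this assay, which is a limit of the assay and not a number.

Compound 3 therefore stands only at the limit of > 50 nM in this assay, at which 1 of the 3 values shown sits, so its place among the measured compounds cannot be fixed. Within the data shown here, the one readable step is a 2.6-fold lower number from compound 1 to compound 2 (0.42 log units; beyond the scatter), where a carboxy group replaced a basic amine side chain. The steps a step that the limit leaves unreadable from compound 1 to compound 3 and a step that the limit leaves unreadable from compound 2 to compound 3 both end at the limit and give no size.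

Compound 4 `CCn1cc(C(CC)(CC)c2ccc(C#CC(O)(CC)CC)c(C)c2)cc1C(=O)N[C@@H](C(=O)O)C(C)C` differs from compound 3 by 1-carboxy-2-methylpropyl in place of 2-carboxyethyl on an amide-type nitrogen. Among the measured compounds shown here, no measured step compares a carboxy chain with and without a branched alkyl substituent, and the only readable step concerns a different kind of exchange, so the expectation for this assay rests on a weak footing and no direction beyond the scatter is predicted. Compound 4 is estimated at 80 nM, with a range from 30 nM to 250 nM. This estimate corresponds to an expected step that the limit leaves unreadable from compound 3 to compound 4.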

Compound 4, half-maximal effective concentration: 68.3 nM
For compound 4 the middle estimate is 1.2-fold (0.07 log units) above the measured one, and the stated range covers the measured number.
By their numbers in this assay, from the lowest: compounds 2 and 4 (each within the scatter of the next); then compound 1.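

In this assay, isopropyl in place of hydrogen on the saturated chain carbon bound to an amide-type nitrogen and a carbonyl carbon gives a 1.3-fold higher number from compound 2 to compound 4 (0.10 log units; within the scatter), so adding this branch produces no change that can be told from scatter. Replacing 3-(dimethylamino)propyl with 1-carboxy-2-methylpropyl on the amide-type nitrogen gives a 2.1-fold lower number from compound 1 to compound 4 (0.32 log units; beyond the scatter), a modest step in the same direction as a 2.6-fold lower number from compound 1 to compound 2 (0.42 log units; beyond the scatter). Both carboxy compounds with readable numbers therefore sit lower than compound 1, while compound 3 cannot be placed in this comparison.

On these data alone, compound 3 stands only at a limit and not a number, so the steps that end at it cannot be read: the limit of > 50 nM in this assay, at which 1 of the 4 values shown sits. Whether a benzyl group on that same chain carbon would also stay within the scatter remains open.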